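A few compounds are considered here, and "the series" means these few. Any claim that something is new, unique, unknown or untested is made for them only; others in the source may bear on it.

`c1ccc(-c2ccc(Cn3nnc4ccccc43)cc2)cc1` compound 1: 7.9 mL/min/g
`Fc1ccc(-c2ccc(Cn3nnc4ccccc43)cc2)c(F)c1` compound 2: 0.9 mL/min/g
`Fc1cc(C(F)(F)F)ccc1-c1ccc(Cn2nnc3ccccc32)cc1` compound 3: not yet measured

Within the data shown here, in an ADME assay on microsomes from liver (Homo sapiens) for metabolic stability, tested at 2.5 uM (a lower number here means slower removal, a higher number faster removal of the compound), compound 2 holds the lower of the two numbers, and the single measured step, an 8.8-fold lower number from compound 1 to compound 2 (0.94 log units; beyond the scatter), sets it apart from compound 1. Compound 3 differs from compound 2 by trifluoromethyl in place of fluoro on an aromatic carbon. Among the measured compounds shown here, no measured step covers this exchange; the only step known describes adding fluoro rather than replacing it, so for this assay a step no larger than the scatter is expected, estimated as a 1.4-fold higher number from compound 2 to compound 3 (0.16 log units; within the scatter). Compound 3 is therefore expected to give about 1.3 mL/min/g, with a range from 0.4 mL/min/g to 4 mL/min/g.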

Compound 3, intrinsic clearance in a liver preparation (reported as CLH), per the amount of preparation that the assay uses: 0.1 mL/min/g
The estimate for compound 3 lay 13-fold (1.11 log units) above the measured number; the measured number lies below the stated range.
By their numbers in this assay, from the lowest: compound 3; then compound 2; then compound 1.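

In this assay the exchange of fluoro for trifluoromethyl, para to a large group and meta to a fluoro group, brings a 9.0-fold lower number from compound 2 to compound 3 (0.95 log units; beyond the scatter) and thus shows that the number at this position can still fall well past the level of compound 2. A group of four heavy atoms is accepted here in place of one, and the number goes down rather than up. No measurement at hand accounts for this drop.

The compounds shown leave open whether the fall depends on fluorine or on group size alone. A methyl group, a nitrile or an amine at this position would help separate the two.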